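The source may hold more compounds than are shown below. What is called first, only, known or untested is meant among the compounds shown, and "the series" means these compounds.

Working notes on the series in a functional assay on HepG2 cells (Homo sapiens) for cytotoxicity, read by MTT assay, with a stated time of 48 h; a higher number here means a weaker inhibitor, a lower number a stronger inhibitor.

Among the compounds with values here, compound 3 (`COc1cc(-c2nnc(SCC(=O)c3ccc(Cl)cc3)n2N2C(=O)c3ccccc3C2=O)cc(OC)c1OC`) is the one member with a read number: in this assay compound 3 gives 22000 nM. Compound 1 (`CCc1nnc(SCC(=O)c2ccc(Cl)cc2)n1N1C(=O)c2ccccc2C1=O`) returns only a limit of the assay, > 200000 nM. Compound 2 (`CCCc1nnc(SCC(=O)c2ccc(Cl)cc2)n1N1C(=O)c2ccccc2C1=O`) likewise returns only a limit, > 200000 nM. Those two limits are the point noted as the limit of > 200000 nM in this assay, at which 2 of the 3 values shown sit, so the step that the two limits leave unreadable from compound 1 to compound 2 cannot be sized. Against them, the steps of an at least 9.0-fold lower number from compound 1 to compound 3 (0.95 log units; beyond the scatter) and an at least 9.0-fold lower number from compound 2 to compound 3 (0.95 log units; beyond the scatter) both show the trimethoxyphenyl-bearing compound 3 stronger by at least that margin.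

Compound 4 (`COc1cc(-c2nnc(SCC(=O)c3ccccc3C)n2N2C(=O)c3ccccc3C2=O)cc(OC)c1OC`) differs from compound 3 only in the aryl ketone, (2-methylphenyl in place of 4-chlorophenyl on a carbonyl carbon). Within the data shown here, no measured step touches this part of the molecule; every measured step concerns the group on the shared core, which is held fixed here. With nothing to anchor a change, the step of no change at the digits printed from compound 3 to compound 4 (within the scatter) is expected to fall within the scatter. Compound 4 is therefore estimated at 22000 nM, with a range from 8000 nM to 60000 nM.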

Compound 4, half-maximal inhibitory concentration: > 200000 nM
Compound 4: no number, only a limit (the forecaster's own chance of this, stated with the estimate: 10%); at least 9.0-fold (0.95 log units) between middle value and limit.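

In this assay the aryl ketone is not a silent part of the molecule: 2-methylphenyl in place of 4-chlorophenyl on a carbonyl carbon gives an at least 9.0-fold higher number from compound 3 to compound 4 (0.95 log units; beyond the scatter) with the 3,4,5-trimethoxyphenyl group held fixed. The earlier steps shown here touched only the group on the shared core, and this step shows that 3,4,5-trimethoxyphenyl alone does not secure a read number. Compound 4 returns a limit of the assay and not a number, which leaves the full size of the step unknown and only compound 3 with a read value: the limit of > 200000 nM in this assay, at which 3 of the 4 values shown sit.

The compounds shown do not separate the exchange of chlorine for methyl from the change in where the substituent sits on the ring; 2-chlorophenyl or 4-methylphenyl on the same carbonyl carbon would bear on this. Also open, on these data alone, is how an amine or a carboxylic acid on that ring would read.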